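Removing a Chloro Group on Two Benzyl Purine Cores

The compounds below may be only part of what the source reports. "The series", "measured", "known", "first", "only" and "open" are said of these compounds alone.

Compound 1 `ClCc1cccc(Cn2cnc3c(Cl)ncnc32)c1`: 18200 nM
Compound 2 `ClCc1ccc(Cn2cnc3nc(Cl)nc(Cl)c32)cc1`: 37200 nM
Compound 3 `ClCc1cccc(Cn2cnc3c(Cl)nc(Cl)nc32)c1`: 5010 nM

Three compounds were measured in a functional assay on PC-3 cells (Homo sapiens) for cytotoxicity, read by sulforhodamine B assay, with a stated time of 48 h; on this read-out higher numbers stand for weaker inhibition of growth and lower numbers for stronger inhibition of growth. Compound 3 gives 5010 nM, compound 1 gives 18200 nM and compound 2 gives 37200 nM; compound 2 stands highest of the three, beyond the scatter from each of the others. Compound 1 arises from compound 3 by one change, (hydrogen in place of chloro on an aromatic carbon), and this brings a 3.6-fold higher number from compound 3 to compound 1 (0.56 log units; beyond the scatter). Compound 2 and compound 3 are built from the same atoms joined differently; the difference between the two cores is not broken down here. Compound 4 `ClCc1ccc(Cn2cnc3ncnc(Cl)c32)cc1` has not yet been measured in this assay. It arises from compound 2 by the same change, (hydrogen in place of chloro on an aromatic carbon), made on the other core. A step of similar size is expected, a 3.0-fold higher number from compound 2 to compound 4 (0.47 log units; beyond the scatter), because a 3.6-fold higher number from compound 3 to compound 1 (0.56 log units; beyond the scatter) lies beyond the scatter and weakened growth inhibition. This expectation rests on a single measured pair and is therefore held loosely. Compound 4 is accordingly estimated at 110000 nM, with a range from 45000 nM to 270000 nM.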

Compound 4, concentration for total growth inhibition: 2950 nM
Beside the measured number, compound 4's estimate is 37-fold (1.57 log units) above it, and the stated range ends above it.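

In this assay, putting hydrogen in place of chloro on an aromatic carbon, between two ring nitrogen atoms, brings a 13-fold lower number from compound 2 to compound 4 (1.10 log units; beyond the scatter), so on this core the loss of the chloro group goes with stronger inhibition of growth. Set beside the earlier pair, the same change does not carry over from one core to the other, in either direction or size: the same change on two cores in this assay, a 3.6-fold higher number (0.56 log units; beyond the scatter) from compound 3 to compound 1 and a 13-fold lower number (1.10 log units; beyond the scatter) from compound 2 to compound 4, 46-fold (1.66 log units) apart, beyond the scatter of two such steps This shows that, in these two pairs, the outcome of the change cannot be read across the cores, but with only one pair on each core it does not show which feature of the cores sets the difference, or whether either step would hold in further compounds.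

All the compounds shown keep a chloromethyl group and at least one chloro group on the core. From the compounds shown here alone, it remains open how an amine or a methoxy group in place of that chloro group, or a hydroxymethyl group in place of the chloromethyl group, would behave on either core.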